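Metabolic stability notes: chloro for fluoro on compound 3

This account rests on a few compounds, and the source may have more. Where it says the series, first, only, none or still open, it means among the compounds named here.

Measured so far:
compound 1, `CNc1nc(NCc2ccc(NC(=O)c3ccc(F)cc3)cc2)c2ccccc2n1`, in an in vitro ADME assay on microsomes from liver (Rattus norvegicus) for metabolic stability (on this read-out lower numbers stand for a shorter-lived compound and higher numbers for a longer-lived compound), gives 0.35 h
compound 2, `CNc1nc(NCc2ccc(NC(=O)c3cccc(Cl)c3)cc2)c2ccccc2n1`, gives 0.25 h
compound 3, `CNc1nc(NCc2ccc(NC(=O)c3ccc(F)cc3)cc2)c2ccc(C)cc2n1`, gives only a limit, > 0.5 h

Compound 3 thus stands at the limit of > 0.5 h in this assay, at which 1 of the 3 values shown sits, with no number of its own. Compound 4, `CNc1nc(NCc2ccc(NC(=O)c3ccc(Cl)cc3)cc2)c2ccc(C)cc2n1`, differs from it by chloro in place of fluoro on an aromatic carbon. Within the data shown here, the only measured step on the ring bearing the carbonyl, a 1.4-fold lower number from compound 1 to compound 2 (0.15 log units; within the scatter), stayed inside the scatter; the other step, an at least 1.4-fold higher number from compound 1 to compound 3 (0.15 log units; that floor lies within the scatter), concerns the methyl and does not bear on this change. Among the measured compounds shown here, no measured pair shows chloro taking the place of fluoro. Hence no step beyond the scatter is expected: for compound 4 the estimated step is a number no higher from compound 3 to compound 4 (the limit leaves the size open). Compound 4 is expected near 0.5 h, between 0.3 h and 1 h, likely again reported as a limit.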

Compound 4, half-life: 0.3 h
The estimate for compound 4 lay 1.7-fold (0.22 log units) above the measured number, within the range that was stated.
By their numbers in this assay, from the lowest: compounds 2, 4 and 1 (each within the scatter of the next). At a limit, above all of these: compound 3.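

In this assay, chloro in place of fluoro on the aromatic carbon para to a large group gets its first direct reading: an at least 1.6-fold lower number from compound 3 to compound 4 (0.22 log units; that floor lies within the scatter). Compound 3 gives only a limit, > 0.5 h, and the floor of the step lies within the scatter. Going by these compounds, the true size of the step stays open because compound 3 has no number of its own: the limit of > 0.5 h in this assay, at which 1 of the 4 values shown sits.

On these data alone, whether the same change reads alike on the core of compound 1, without the methyl, remains open. So does how a trifluoromethyl, nitrile or methoxy group would read at this carbon.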